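This account rests on a few compounds, and the source may have more. Where it says the series, first, only, none or still open, it means among the compounds named here.

Measured in a functional assay on HeLa cells (Homo sapiens) for inhibition, read by MTT assay, with a stated time of 72 h; on this read-out lower numbers stand for stronger inhibition and higher numbers for weaker inhibition:
compound 1 `CCc1ccc(C(=O)/C=C/C(=O)O)cc1` — 27800 nM
compound 2 `O=C(O)/C=C/C(=O)c1ccc(Br)cc1` — 18700 nM
compound 3 `O=C(O)/C=C/C(=O)c1ccc(Cl)cc1` — 25400 nM

Compound 3 stands second highest of the three numbers; its nearest neighbour is compound 1 and its furthest compound 2, and every step among the three lies within the scatter: a 1.5-fold lower number from compound 1 to compound 2 (0.17 log units; within the scatter), a 1.1-fold lower number from compound 1 to compound 3 (0.04 log units; within the scatter), a 1.4-fold higher number from compound 2 to compound 3 (0.13 log units; within the scatter).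

Compound 4 `CC(C)c1ccc(C(=O)/C=C/C(=O)O)cc1` is not yet measured. Change: isopropyl in place of chloro on an aromatic carbon. The step that bears on it is the one exchanging an alkyl for a halogen, a 1.1-fold lower number from compound 1 to compound 3 (0.04 log units; within the scatter), which stayed within the scatter; here an alkyl again replaces the halogen, so no step beyond the scatter in this assay is expected. Compound 4 is therefore estimated at 26000 nM, between 13000 nM and 52000 nM. For compound 4 this expectation means a 1.0-fold higher number from compound 3 to compound 4 (0.01 log units; within the scatter).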

Compound 4, half-maximal inhibitory concentration: 4900 nM
Beside the measured number, compound 4's estimate is 5.3-fold (0.72 log units) above it; measured number outside the range, below it.
By their numbers in this assay, from the lowest: compound 4; then compounds 2, 3 and 1 (each within the scatter of the next).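

At this position, on an aromatic carbon para to a group of 7 heavy atoms, the substituent now registers: isopropyl gives a 5.2-fold lower number from compound 3 to compound 4 (0.71 log units; beyond the scatter) and a 3.8-fold lower number from compound 2 to compound 4 (0.58 log units; beyond the scatter) in exchange for the halogens, whereas ethyl, bromo and chloro stayed within the scatter of one another. Methyl in place of hydrogen on the saturated chain carbon bound to the aromatic carbon gives a 5.7-fold lower number from compound 1 to compound 4 (0.75 log units; beyond the scatter) on its own, so ethyl and isopropyl do not read alike. No supporting data on the origin of these steps are available.

Open, on these data alone, is how tert-butyl, cyclopropyl or a longer chain at this position would compare with isopropyl, and whether an amine or a methoxy there would read like the halogens.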